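Working notes: from propoxy to benzyloxy

The compounds below may be only part of what the source reports. "The series", "measured", "known", "first", "only" and "open" are said of these compounds alone.

Measured so far:
- compound 1 `COc1ccc(C(=O)/C=C/c2ccccc2)c(O)c1Br`: > 50000 nM
- compound 2 `CCCOc1ccc(C(=O)/C=C/c2ccccc2)c(O)c1`: > 50000 nM

In a functional assay on Ca-Ski cells (Homo sapiens) for antiproliferative activity, with a stated time of 48 h (on this read-out lower numbers stand for stronger inhibition and higher numbers for weaker inhibition), compound 2 gives > 50000 nM, which is a limit of the assay and not a number. Among the compounds with values here, the series so far stands at the limit of > 50000 nM in this assay, at which 2 of the 2 values shown sit. Neither compound therefore offers a numerical starting point.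

Compound 3 `O=C(/C=C/c1ccccc1)c1ccc(OCc2ccccc2)cc1O` has phenyl in place of ethyl on a saturated chain carbon bound to an oxygen on an aromatic ring, which turns propoxy into benzyloxy (phenyl in place of ethyl on a saturated chain carbon bound to an oxygen on an aromatic ring).

Within the data shown here, no measured pair provides a step to go by. A modest step towards stronger inhibition in this assay is expected, although a result that is again only a limit remains quite possible. This expectation starts from compound 2 at > 50000 nM, and that value is only a limit. The expected change is an at least 1.2-fold lower number from compound 2 to compound 3 (0.09 log units; that floor lies within the scatter), an estimate with wide uncertainty. Compound 3 is estimated at 40000 nM. The expected range for this estimate runs from 15000 nM to 100000 nM.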

Compound 3, half-maximal inhibitory concentration: > 50000 nM
Compound 3 was reported as a limit; the forecaster's own chance of this, stated with the estimate: 55%; middle value at least 1.2-fold (0.09 log units) away from the limit.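

In this assay compound 3 gives > 50000 nM, which is a limit of the assay and not a number. Within the data shown here, compound 2 is likewise reported only as a limit, and no step from compound 2 to compound 3 can be read. The compounds shown leave open whether propoxy and benzyloxy differ at all in this read-out, and the series offers no numerical value: the limit of > 50000 nM in this assay, at which 3 of the 3 values shown sit.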